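A few compounds are considered here, and "the series" means these few. Any claim that something is new, unique, unknown or untested is made for them only; others in the source may bear on it.

Two compounds with the same core differ only in the aryl group attached to the sulfonyl sulfur. Compound 1 `COc1ccc(S(=O)(=O)Nc2ccc(-c3nc4ccccc4o3)cc2)cc1` carries a 4-methoxyphenyl there. In an assay on cells for inhibition of HSP60/HSP10 (Homo sapiens), with a stated time of 60 min (a lower number here means a stronger inhibitor, a higher number a weaker inhibitor), compound 1 gives > 100000 nM, which is a limit of the assay rather than a measured number. Compound 2 `Cc1cccc(S(=O)(=O)Nc2ccc(-c3nc4ccccc4o3)cc2)c1` carries a 3-methylphenyl instead. In this assay compound 2 gives > 100000 nM, again a limit. Among the compounds with values here, the step that the two limits leave unreadable from compound 1 to compound 2 therefore cannot be read, and all that is known of compound 2 is this limit, shared with the one other value shown (the limit of > 100000 nM in this assay, at which 2 of the 2 values shown sit).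

Compound 3 `O=S(=O)(Nc1ccc(-c2nc3ccccc3o2)cc1)c1ccc(Cl)cc1` is not yet measured. It differs from compound 2 by 4-chlorophenyl in place of 3-methylphenyl on a sulfonyl sulfur. Within the data shown here, no measured step gives a readable size for a change of this kind, since both values shown sit at the same limit (the limit of > 100000 nM in this assay, at which 2 of the 2 values shown sit). Compound 3 is therefore expected to give about 200000 nM, within 50000 nM to 1000000 nM. That estimate means an expected step that the limit leaves unreadable from compound 2 to compound 3, most probably again only a limit.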

Compound 3, half-maximal inhibitory concentration: 61000 nM
Estimate against measurement, compound 3: 3.3-fold (0.52 log units) above, within the range that was stated.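

Within the data shown here, compound 3, with its 4-chlorophenyl on the sulfonyl sulfur, gives 61000 nM in this assay, the first real number here rather than a limit, so a change at this position can yield a readable value. As far as these compounds go, the change reads as an at least 1.6-fold lower number from compound 2 to compound 3 (0.21 log units; that floor lies within the scatter) and as an at least 1.6-fold lower number from compound 1 to compound 3 (0.21 log units; that floor lies within the scatter); each is only a floor, so the true size of both steps stays unknown, and neither floor goes beyond the usual scatter. Both floors rest on the same limit: the limit of > 100000 nM in this assay, at which 2 of the 3 values shown sit.

The compounds shown leave open whether the chloro group must sit where it does in the 4-chlorophenyl, which a 3-chlorophenyl on the same sulfur would test. They also leave open what an amine or a carboxylic acid on that aromatic ring would give.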